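The source may hold more compounds than are shown below. What is called first, only, known or untested is meant among the compounds shown, and "the series" means these compounds.

Compound 1 `CC#CC(CC(=O)O)c1ccc(OCc2ccc3nc(-c4ccc(F)cc4F)cn3c2)cc1` gives 825 nM in an assay on isolated protein for agonist activity at Free fatty acid receptor 1 (Homo sapiens) (on this read-out higher numbers stand for an effect only at larger amounts of compound and lower numbers for an effect already at smaller amounts), the highest of the three numbers shown. Compound 2 `CC#CC(CC(=O)O)c1ccc(OCc2ccn3cc(-c4ccc(F)cc4)nc3c2)cc1` gives 783 nM, within the scatter of compound 1, while compound 3 `CC#CC(CC(=O)O)c1ccc(OCc2ccc3nc(-c4ccc(OC)cc4)cn3c2)cc1` gives 47 nM. Among the compounds with values here, the one step that starts from compound 1 is an 18-fold lower number from compound 1 to compound 3 (1.24 log units; beyond the scatter), where 4-methoxyphenyl replaces 2,4-difluorophenyl. Compound 4 `CC#CC(CC(=O)O)c1ccc(OCc2ccc3nc(-c4ccc(C5CCCCC5)cc4)cn3c2)cc1` differs from compound 1 by 4-cyclohexylphenyl in place of 2,4-difluorophenyl on an aromatic carbon, again removing the 2,4-difluorophenyl in favour of a phenyl carrying a single group. Because the step of an 18-fold lower number from compound 1 to compound 3 (1.24 log units; beyond the scatter) was large, a lower number is expected for compound 4, though the size of the new group is not sampled among the measured compounds, so the expected step of a 6.9-fold lower number from compound 1 to compound 4 (0.84 log units; beyond the scatter) is taken somewhat smaller. Compound 4 is therefore estimated at 120 nM, with a range from 30 nM to 500 nM.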

Compound 4, half-maximal effective concentration: 417 nM
The estimate for compound 4 lay 3.5-fold (0.54 log units) below the measured number; low and high end bracket the measured number.
By their numbers in this assay, from the lowest: compound 3; then compounds 4, 2 and 1 (each within the scatter of the next).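

In this assay, 4-cyclohexylphenyl in place of 2,4-difluorophenyl gives a 2.0-fold lower number from compound 1 to compound 4 (0.30 log units; within the scatter) and so does not repeat the step seen with 4-methoxyphenyl. Cyclohexyl in place of methoxy gives an 8.9-fold higher number from compound 3 to compound 4 (0.95 log units; beyond the scatter) and shows that at this position the group on the phenyl matters, not merely the removal of the 2,4-difluorophenyl. Nothing available explains the difference between these two groups. From the compounds shown here alone, whether an ethoxy, a hydroxyl or a dimethylamino group on that phenyl would behave like methoxy or like cyclohexyl remains open.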